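The compounds below may be only part of what the source reports. "The series", "measured", "known", "first", "only" and "open" are said of these compounds alone.

Compound 1 `CN1CCN(C(=O)c2cccc(CN3CCN(C(=O)n4nnc5ccccc54)CC3)c2)CC1`: 1380 nM
Compound 2 `O=C(NC1CCCCC1)c1cccc(CN2CCN(C(=O)n3nnc4ccccc43)CC2)c1`: 44 nM

In an assay on isolated protein for inhibition of Fatty-acid amide hydrolase 1 (Homo sapiens), read by scintillation counting, with stated times of 30 min and 10 min (on this read-out higher numbers stand for weaker inhibition and lower numbers for stronger inhibition), compound 2 gives 44 nM, the lower of the two numbers; its nearest neighbour is compound 1, which gives 1380 nM, and the step of a 31-fold lower number from compound 1 to compound 2 (1.50 log units; beyond the scatter) separates them. Compound 3 `O=C(Nc1ccccc1)c1cccc(CN2CCN(C(=O)n3nnc4ccccc43)CC2)c1` differs from compound 2 by phenyl in place of cyclohexyl on an amide-type nitrogen. Within the data shown here, no measured step bears on this change: the one known step replaces a different group and gives no guide to direction. Compound 3 is therefore expected to land close to compound 2, with a step of a 1.6-fold higher number from compound 2 to compound 3 (0.20 log units; within the scatter) that stays within the scatter. The estimate for compound 3 in this assay is 70 nM, ranging from 20 nM to 250 nM.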

Compound 3, half-maximal inhibitory concentration: 35 nM
Compound 3: the middle estimate sits 2.0-fold (0.30 log units) above what was measured, and the stated range covers the measured number.
By their numbers in this assay, from the lowest: compounds 3 and 2 (each within the scatter of the next); then compound 1.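

In this assay, phenyl serves in place of cyclohexyl on the amide-type nitrogen with no change beyond the scatter (a 1.3-fold lower number from compound 2 to compound 3 (0.10 log units; within the scatter)). The secondary amide's advantage over the 4-methylpiperazin-1-yl amide therefore does not depend on a non-aromatic ring, and it holds for anilino too (a 39-fold lower number from compound 1 to compound 3 (1.60 log units; beyond the scatter)). No evidence here explains why these two rings read alike. The compounds shown leave open whether an open chain such as n-butyl can replace the ring on this nitrogen. They also leave open how a carboxylic acid or an amine on the phenyl ring would read.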